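Removing the Halogen from the Anilide Ring

The compounds below may be only part of what the source reports. "The series", "measured", "known", "first", "only" and "open" are said of these compounds alone.

Measured compounds:
compound 1 `CC1CCN(S(=O)(=O)N2CCN(CC(=O)Nc3cccc(F)c3)CC2)CC1`, 4600 nM
compound 2 `CC1CCN(S(=O)(=O)N2CCN(CC(=O)Nc3cccc(Cl)c3)CC2)CC1`, 7600 nM

In an assay on HEK293 cells for activation of potassium channel subfamily T member 1 (Homo sapiens), read by thallium flux (on this read-out higher numbers stand for an effect only at larger amounts of compound and lower numbers for an effect already at smaller amounts), compound 1 gives 4600 nM, and in this assay compound 2 gives 7600 nM. Going by the values given here, compound 2 thus carries the higher of the two numbers, but the one measured step, a 1.7-fold higher number from compound 1 to compound 2 (0.22 log units; within the scatter), stays within the scatter, so the two halogenated anilides cannot be told apart on this read-out.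

Compound 3 `CC1CCN(S(=O)(=O)N2CCN(CC(=O)Nc3ccccc3)CC2)CC1` has not yet been measured. It differs from compound 2 in one place: hydrogen in place of chloro on an aromatic carbon. Among the compounds with values here, no measured pair shows the loss of a halogen from this ring, so only the step from compound 1 to compound 2 bears on the question, and it was within the scatter. Swapping one halogen for another at this position left the number essentially unchanged, which gives no ground to expect that taking the halogen away altogether will move it beyond the scatter either.

The estimated step is therefore a 1.3-fold lower number from compound 2 to compound 3 (0.10 log units; within the scatter), meaning no change beyond the scatter. Compound 3 is expected to give 6000 nM in this assay, with a range from 2500 nM to 15000 nM.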

Compound 3, half-maximal effective concentration: > 10000 nM
Compound 3: only a limit was reported (the forecaster's own chance of this, stated with the estimate: 10%); middle value at least 1.6-fold (0.22 log units) away from the limit.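

In this assay compound 3 is reported only as a limit, > 10000 nM being the figure given. Taking the fluoro group off the ring gives an at least 2.1-fold higher number from compound 1 to compound 3 (0.33 log units; beyond the scatter) and so is the only change at this position among the compounds shown that is printed as beyond the scatter, whereas exchanging one halogen for the other had left the two anilides indistinguishable. Taking the chloro group off gives an at least 1.3-fold higher number from compound 2 to compound 3 (0.11 log units; that floor lies within the scatter) and so cannot yet be told from the scatter, and the reading of both changes stops at the same point: the limit of > 10000 nM in this assay, at which 1 of the 3 values shown sits.

The compounds shown leave open how far compound 3 actually lies past its limit, and with it how large the loss of either halogen is on this read-out. They also leave open whether the gain over the plain phenyl belongs to halogens alone or would also come with a methyl, a methoxy or a nitrile on the same aromatic carbon.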